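Acyloxy substitution on the chromane core: compound 4 notes

This account rests on a few compounds, and the source may have more. Where it says the series, first, only, none or still open, it means among the compounds named here.

Within the data shown here, compound 1 `Cc1cc(C)c2c(c1C)OC(C)(COc1ccc(CC3SC(=O)NC3=O)cc1)CC2` gives 12300 nM in a functional assay on MDA-MB-231 cells (Homo sapiens) for antiproliferative activity, read by luminescence, with a stated time of 24 h (a higher number here means a weaker inhibitor, a lower number a stronger inhibitor), the highest of the three numbers measured so far. Among the measured compounds shown here, compound 2 `Cc1c(C)c2c(c(C)c1OC(=O)CCCCCCCN)CCC(C)(COc1ccc(/C=C3\SC(=O)NC3=O)cc1)O2` gives 5000 nM and compound 3 `Cc1c(C)c2c(c(C)c1OC(=O)CCCCCCCNC(=O)OC(C)(C)C)CCC(C)(COc1ccc(/C=C3\SC(=O)NC3=O)cc1)O2` gives 3200 nM; the one single-point step among them, a 1.6-fold lower number from compound 2 to compound 3 (0.19 log units; within the scatter), carries a tert-butoxycarbonyl in place of hydrogen on an amine nitrogen. Compound 4 `Cc1c(C)c2c(c(C)c1OC(=O)CCC(=O)O)CCC(C)(COc1ccc(CC3SC(=O)NC3=O)cc1)O2` differs from compound 1 by ((2-carboxyethyl)carbonyl)oxy in place of hydrogen on an aromatic carbon. For the measured compounds named here, no measured step covers this exact change; compounds 2 and 3 carry a different acyloxy group at that carbon together with a second change, so their lower numbers bear only loosely on it. The expected outcome is a modest step downward, a 2.1-fold lower number from compound 1 to compound 4 (0.31 log units; beyond the scatter), with compound 4 estimated at 6000 nM within 2500 nM to 15000 nM.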

Compound 4, half-maximal inhibitory concentration: > 25000 nM
Compound 4: only a limit was reported (the forecaster's own chance of this, stated with the estimate: 10%); middle value at least 4.1-fold (0.61 log units) away from the limit.
By their numbers in this assay, from the lowest: compounds 3 and 2 (each within the scatter of the next); then compound 1. At a limit, above all of these: compound 4.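

In this assay, among these compounds, the first single-point step at this aromatic carbon reads an at least 2.0-fold higher number from compound 1 to compound 4 (0.30 log units; that floor lies within the scatter) and brings no lower number with ((2-carboxyethyl)carbonyl)oxy in place of hydrogen. The step gives only a floor, so it sets no size for the change. Compound 4 is reported only as a limit: the limit of > 25000 nM in this assay, at which 1 of the 4 values shown sits.

Still open, as far as these compounds go, are the true size of this step and whether a terminal amine, or a methyl ester in place of the carboxylic acid, on the core of compound 1 would lower the number.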